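One More Methoxy on a Shared Core

This account rests on a few compounds, and the source may have more. Where it says the series, first, only, none or still open, it means among the compounds named here.

Of the compounds shown here, three have been tested in a functional assay on MDA-MB-468 cells (Homo sapiens) for cytotoxicity, read by sulforhodamine B assay, with a stated time of 48 h, tested at 0.1 uM; a lower number here means a stronger effect, a higher number a weaker effect of the compound at the concentration tested. Compound 1 (`COc1ccc(-c2cc(/C=C/C(=O)c3ccc(N)cc3)[nH]n2)cc1`) gives 86% in this assay. Compound 3 (`COc1ccc(-c2cc(/C=C/C(=O)c3ccc(N)cc3)[nH]n2)cc1OC`) differs from compound 1 by methoxy in place of hydrogen on an aromatic carbon, and in this assay compound 3 gives 91%. The step of a number 5 percentage points higher from compound 1 to compound 3 (within the scatter) therefore changes little. Compound 2 (`COc1ccc(C(=O)/C=C/c2cc(-c3cc(OC)c(OC)c(OC)c3)n[nH]2)cc1OC`) carries a different core from compound 1, and the difference between the two cores is not broken down here; in this assay compound 2 gives 89%, a number that sits within the scatter of both compound 1 and compound 3, so no order among the three can be read from these values.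

Compound 4 (`COc1cc(C(=O)/C=C/c2cc(-c3cc(OC)c(OC)c(OC)c3)n[nH]2)cc(OC)c1OC`) has not been measured in this assay. It differs from compound 2 by methoxy in place of hydrogen on an aromatic carbon. Among the compounds with values here, this is the same kind of change as the one from compound 1 to compound 3, though the surroundings are not identical: in compound 4 the entering group is also meta to a methoxy group, which is not the case for compound 3. Since the earlier step of a number 5 percentage points higher from compound 1 to compound 3 (within the scatter) stayed within the scatter, a similarly small step is expected here, estimated as a number 2 percentage points higher from compound 2 to compound 4 (within the scatter). On that basis compound 4 is expected to give about 91% in this assay, most likely between 80% and 99%.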

Compound 4, a percentage reported as activity, at one concentration (the size of the read-out at that concentration, not a potency): 84%
Estimate against measurement, compound 4: 7 percentage points above, and the stated range covers the measured number.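

In this assay, the new step is a number 5 percentage points lower from compound 2 to compound 4 (within the scatter), and the change is again methoxy in place of hydrogen on an aromatic carbon. Set beside the step made by the same change on the other core, a number 5 percentage points higher from compound 1 to compound 3 (within the scatter), the new step gives no sign that the core alters what this change does: the same change on two cores in this assay, a number 5 percentage points higher (within the scatter) from compound 1 to compound 3 and a number 5 percentage points lower (within the scatter) from compound 2 to compound 4, 10 percentage points apart, within the scatter of two such steps. Within the data shown here, this shows that, in these two pairs, the added methoxy leaves the read-out within the usual spread of repeated measurements, and that the opposite directions of the two steps should not be read as a real difference between the cores, but it does not show that the change is without effect in general or that it would behave alike on every core, since only two pairs at one tested concentration are available.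

The compounds shown leave open whether a different group on the same aromatic ring, such as a hydroxyl, a chlorine atom or the longer ethoxy chain, would move the number beyond the scatter. They also leave open whether a carboxylic acid in place of the amine of compound 1 would change the read-out.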